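A few compounds are considered here, and "the series" means these few. Any claim that something is new, unique, unknown or untested is made for them only; others in the source may bear on it.

Measured compounds so far:

- compound 1 `Cc1cc(C)c(S(=O)(=O)N2CCC(N3CCC(O)CC3)CC2)c(C)c1`; in an ADME assay on HCT-116 cells (Homo sapiens) for cytotoxicity, read by CellTiter-Glo, with a stated time of 72 h (on this read-out lower numbers stand for stronger inhibition and higher numbers for weaker inhibition), compound 1 gives > 5000 nM, a limit of the assay rather than a number.
- compound 2 `Cc1cc(C)cc(-c2cccc(S(=O)(=O)N3CCC(N4CCC(C)CC4)CC3)c2)c1`; in this assay compound 2 gives > 5000 nM, again a limit.
- compound 3 `CC1CCN(C2CCN(S(=O)(=O)c3cnc(Cl)s3)CC2)CC1`; in this assay compound 3 gives > 10000 nM, also a limit.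

Compound 1 therefore stands where all three measured members stand: at a limit, with no number behind it. Among the measured compounds shown here, two of the values sit at the limit of > 5000 nM in this assay, at which 2 of the 3 values shown sit, and one at the limit of > 10000 nM in this assay, at which 1 of the 3 values shown sits, so nothing so far shows measurable cytotoxicity.

The next compound is compound 4 `Cc1cc(C)c(S(=O)(=O)N2CCC(C(=O)N3CCC(C)CC3)CC2)c(C)c1`. Its change from compound 1 is (4-methylpiperidin-1-yl)carbonyl in place of 4-hydroxypiperidin-1-yl on a saturated ring carbon. For the measured compounds named here, no measured pair differs in one place, so there is no step of known size to lean on. Given that compound 1 gives > 5000 nM, no movement beyond the scatter is expected, and the step that the limit leaves unreadable from compound 1 to compound 4 is estimated as essentially flat. Compound 4 is expected to give about 10000 nM, with a likely range from 3000 nM to 30000 nM, most probably reported as a limit again.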

Compound 4, half-maximal inhibitory concentration: > 5000 nM
Compound 4 gave a limit, no number; the forecaster's own chance of this, stated with the estimate: 80%; the middle value does not contradict the limit.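

In this assay, among the compounds shown here, compound 1 and compound 4 both give limits, not numbers, so no step between them can be read. The compounds shown leave open whether any member reaches a measurable value and what (4-methylpiperidin-1-yl)carbonyl in place of 4-hydroxypiperidin-1-yl does to it.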